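A few compounds are considered here, and "the series" means these few. Any claim that something is new, unique, unknown or untested is made for them only; others in the source may bear on it.

Measured in a functional assay for inhibition, with Rattus norvegicus as the target; on this read-out lower numbers stand for stronger inhibition and higher numbers for weaker inhibition:
- compound 1 `CC(/N=c1\c(O)c(O)\c1=N/c1cccc2cccnc12)C(C)(C)C`: 8100 nM
- compound 2 `C[C@@H](/N=c1\c(O)c(O)\c1=N/c1ccc2c[nH]nc2c1)C(C)(C)C`: 4600 nM
- compound 3 `CC(/N=c1\c(O)c(O)\c1=N/c1ccc(S(N)(=O)=O)cc1)C(C)(C)C`: > 30000 nM, a limit and not a number

Compound 3 stands at the limit of > 30000 nM in this assay, at which 1 of the 3 values shown sits. That entry is a limit, so compound 3 has no exact position on the scale.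

Compound 4 `CC(/N=c1\c(O)c(O)\c1=N/c1ccc(C(F)(F)F)cc1)C(C)(C)C` differs from compound 3 in one place, with trifluoromethyl in place of sulfamoyl on an aromatic carbon, para to a large group: trifluoromethyl in place of sulfamoyl on an aromatic carbon. Among the measured compounds shown here, no measured pair in this small set isolates a single change, so any forecast for this swap rests on thin ground.

For the measured compounds named here, the other two compounds offer the only guide. In this assay compound 1 gives 8100 nM, and compound 2 gives 4600 nM. Going by the values given here, both therefore return actual numbers, with aromatic groups different from the one in compound 3. On that basis, compound 4 is expected to give a measurable value on the stronger side of the limit reached by compound 3, though a second limit cannot be ruled out. The estimated change is an at least 20-fold lower number from compound 3 to compound 4 (1.30 log units; beyond the scatter), in the direction of stronger inhibition. For compound 4 the expected value is 1500 nM, with an estimated range of 150 nM to 12000 nM.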

Compound 4, half-maximal inhibitory concentration: > 30000 nM
Compound 4: only a limit was reported; the forecaster's own chance of this, stated with the estimate: 8%; at least 20-fold (1.30 log units) between middle value and limit.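

In this assay compound 4 gives > 30000 nM, which is a limit and not a number. Compound 3 also has only a limit, so no step can be read between compound 3 and compound 4. The compounds shown leave open whether trifluoromethyl in place of sulfamoyl changes inhibition in this read-out, and by how much.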